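Aryl swap on the amine nitrogen: compound 3 to compound 4

The source may report more compounds than this note shows. Statements on the series, on what has been measured and on what is new or still open speak of the compounds shown alone.

Three aryl amines on the shared core have numbers in a functional assay on HT-29 cells (Homo sapiens) for cytotoxicity, read by sulforhodamine B assay; on this read-out higher numbers stand for weaker inhibition and lower numbers for stronger inhibition. Compound 1 (`C=C1[C@@H](OC(C)=O)C[C@@H]2[C@](C)(CO[Si](C)(C)C(C)(C)C)[C@H](OC(C)=O)CC[C@@]2(C)[C@@H]1C[C@@H](Nc1ccc(OC)c(OC)c1)C1=CCOC1=O`) gives 5330 nM, compound 2 (`C=C1[C@@H](OC(C)=O)C[C@@H]2[C@](C)(CO[Si](C)(C)C(C)(C)C)[C@H](OC(C)=O)CC[C@@]2(C)[C@@H]1C[C@@H](Nc1ccc(O)cc1)C1=CCOC1=O`) gives 6140 nM, and compound 3 (`C=C1[C@@H](OC(C)=O)C[C@@H]2[C@](C)(CO[Si](C)(C)C(C)(C)C)[C@H](OC(C)=O)CC[C@@]2(C)[C@@H]1C[C@@H](Nc1ccc(C(=O)O)cc1)C1=CCOC1=O`) gives 4630 nM. Compound 3 thus sits within the scatter of both others.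

Compound 4 (`C=C1[C@@H](OC(C)=O)C[C@@H]2[C@](C)(CO[Si](C)(C)C(C)(C)C)[C@H](OC(C)=O)CC[C@@]2(C)[C@@H]1C[C@@H](Nc1cccc(OC)c1)C1=CCOC1=O`) has 3-methoxyphenyl in place of 4-carboxyphenyl on an amine nitrogen.

Among the measured compounds shown here, no measured compound carries this exact aryl group, so the evidence is indirect. The closest step is a 1.2-fold lower number from compound 1 to compound 3 (0.06 log units; within the scatter), which exchanges 3,4-dimethoxyphenyl and 4-carboxyphenyl. The other two steps are a 1.3-fold lower number from compound 2 to compound 3 (0.12 log units; within the scatter) and a 1.2-fold higher number from compound 1 to compound 2 (0.06 log units; within the scatter). All three stay within the scatter, so no step beyond the scatter is expected in this assay.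

The estimated change is a 1.1-fold higher number from compound 3 to compound 4 (0.05 log units; within the scatter), which points in no meaningful direction. Compound 4 is estimated at 5200 nM, with an expected range of 3000 nM to 8500 nM.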

Compound 4, half-maximal inhibitory concentration: > 50000 nM
Compound 4 gave a limit, no number; the forecaster's own chance of this, stated with the estimate: 3%; middle value at least 9.6-fold (0.98 log units) from the limit.
By their numbers in this assay, from the lowest: compounds 3, 1 and 2 (each within the scatter of the next). At a limit, above all of these: compound 4.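

In this assay compound 4 stands at a limit, not a number: the limit of > 50000 nM in this assay, at which 1 of the 4 values shown sits.

The three earlier aryl amines stayed within the scatter of one another, but the aryl group on the amine nitrogen clearly matters here, with an at least 10-fold higher number from compound 3 to compound 4 (1.03 log units; beyond the scatter), an at least 8.1-fold higher number from compound 2 to compound 4 (0.91 log units; beyond the scatter) and an at least 9.3-fold higher number from compound 1 to compound 4 (0.97 log units; beyond the scatter). The last of these is the smallest change in structure, hydrogen in place of methoxy on an aromatic carbon, so a single methoxy separates compound 1 from compound 4 in this series.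

Going by these compounds, the true size of all three steps stays open, since each rests on a limit. Also open, on these data alone, is whether an unsubstituted phenyl or a simple alkyl chain on the amine nitrogen would fall with compound 4 or with compounds 1, 2 and 3.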